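Fluorophenyl isomers in the series

The source may report more compounds than this note shows. Statements on the series, on what has been measured and on what is new or still open speak of the compounds shown alone.

Among the measured compounds shown here, in a toxicity assay on HaCaT cells (Homo sapiens) for cytotoxicity, read by CCK-8 assay, with a stated time of 24 h (a lower number here means that less compound is tolerated, a higher number that more compound is tolerated), compound 2 (`COc1ccccc1Oc1c(N)nc(-c2ccccc2F)nc1OCCO`) gives 39500 nM, the higher of two numbers so far. Compound 1 (`COc1cccc(-c2nc(N)c(Oc3ccccc3OC)c(OCCO)n2)c1`) gives 12700 nM. Compound 3 (`COc1ccccc1Oc1c(N)nc(-c2ccc(F)cc2)nc1OCCO`) is unmeasured and carries 4-fluorophenyl in place of 2-fluorophenyl on an aromatic carbon. For the measured compounds named here, the only measured step at this place is modest, a 3.1-fold higher number from compound 1 to compound 2 (0.49 log units; beyond the scatter), and it exchanges a different group. Going by the values given here, no measured pair compares fluorine positions, so a smaller change is expected, with no firm direction. The expected step is a 1.3-fold lower number from compound 2 to compound 3 (0.12 log units; within the scatter), not beyond the scatter. For compound 3 the estimated value is 30000 nM, with a range of 13000 nM to 70000 nM.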

Compound 3, half-maximal cytotoxic concentration: 15100 nM
Compound 3: the middle estimate sits 2.0-fold (0.30 log units) above what was measured; low and high end bracket the measured number.
By their numbers in this assay, from the lowest: compounds 1 and 3 (each within the scatter of the next); then compound 2.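

Fluorine position on the phenyl group counts at this place: in this assay, 4-fluorophenyl in place of 2-fluorophenyl gives a 2.6-fold lower number from compound 2 to compound 3 (0.42 log units; beyond the scatter) on the shared core. Against 3-methoxyphenyl, 4-fluorophenyl gives a 1.2-fold higher number from compound 1 to compound 3 (0.08 log units; within the scatter) and so does not share the higher number of 2-fluorophenyl, which therefore cannot be read as a feature of fluorophenyl groups in general. Nothing on hand accounts for the gap between the two isomers.

Open, from the compounds shown here alone, is where 3-fluorophenyl would fall, and whether 2-chlorophenyl follows 2-fluorophenyl. Also open, going by these compounds, is whether the gap between the isomers survives a longer chain in place of the 2-hydroxyethoxy group.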